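Swapping an ortho methoxy for chloro on an aryl nitrogen

The source may report more compounds than this note shows. Statements on the series, on what has been measured and on what is new or still open speak of the compounds shown alone.

Measured compounds:
- compound 1, `COc1ccccc1-n1c(-c2coc3cc(C)c(Cl)cc3c2=O)nc(-c2ccccc2)c1-c1ccccc1`, 12500 nM
- compound 2, `Cc1cc2occ(-c3nc(-c4ccccc4)c(-c4ccccc4)n3-c3ccc(Cl)c(Cl)c3)c(=O)c2cc1Cl`, 12500 nM
- compound 3, `Cc1ccc(-n2c(-c3coc4cc(C)c(Cl)cc4c3=O)nc(-c3ccccc3)c2-c2ccccc2)c(C)c1`, 3120 nM

In a functional assay on HepG2 cells (Homo sapiens) for inhibition, read by MTT assay, with a stated time of 72 h (a higher number here means a weaker inhibitor, a lower number a stronger inhibitor), compound 1 gives 12500 nM. Compound 1 and compound 2 sit level at the digits shown, and together they carry the highest numbers of the three; compound 3 alone lies lower, a 4.0-fold lower number from compound 1 to compound 3 (0.60 log units; beyond the scatter).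

Compound 4 is `Cc1cc2occ(-c3nc(-c4ccccc4)c(-c4ccccc4)n3-c3ccccc3Cl)c(=O)c2cc1Cl`. It differs from compound 1 in one place: chloro in place of methoxy on an aromatic carbon.

Among the measured compounds shown here, two measured steps bear on this change, both altering the same ring on the aromatic nitrogen of the shared core. Going from compound 1 to compound 2, which puts chlorine on that ring in other positions, gave no change at the digits printed from compound 1 to compound 2 (within the scatter). Going to compound 3 gave a 4.0-fold lower number from compound 1 to compound 3 (0.60 log units; beyond the scatter), and from compound 2 to compound 3 likewise a 4.0-fold lower number from compound 2 to compound 3 (0.60 log units; beyond the scatter). For the measured compounds named here, no measured step exchanges a single ortho group for chloro alone, so the closest guide is the chlorine-bearing compound 2, which stays level with compound 1.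

Compound 4 is therefore expected to show little movement beyond the scatter, with the estimated step of a 1.3-fold lower number from compound 1 to compound 4 (0.10 log units; within the scatter) and an estimate of 10000 nM, ranging from 3000 nM to 30000 nM.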

Compound 4, half-maximal inhibitory concentration: 6250 nM
Estimate against measurement, compound 4: 1.6-fold (0.20 log units) above, within the range that was stated.
By their numbers in this assay, from the lowest: compounds 3, 4, 1 and 2 (each within the scatter of the next, the first and the last beyond it).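

In this assay, the exchange of methoxy for chloro, ortho to a large group, gives a 2.0-fold lower number from compound 1 to compound 4 (0.30 log units; within the scatter), so this single swap, isolated from any other change on the ring, stays within the scatter. Compound 4 also fills the gap between two compounds that stand apart, a 4.0-fold lower number from compound 2 to compound 3 (0.60 log units; beyond the scatter), since both a 2.0-fold higher number from compound 3 to compound 4 (0.30 log units; within the scatter) and a 2.0-fold lower number from compound 2 to compound 4 (0.30 log units; within the scatter) are within the scatter, leaving compound 4 indistinguishable from either one. Nothing measured here offers an explanation for these numbers.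

The compounds shown leave open how a different kind of group at this place, such as an amine, a carboxylic acid or a longer chain, would read in this assay. They also leave open whether 2-methoxyphenyl to 2-chlorophenyl would behave the same way on another core.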